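Trimethoxyphenyl pyrazolyl enones: adding a methoxy to compound 2

The compounds below may be only part of what the source reports. "The series", "measured", "known", "first", "only" and "open" are said of these compounds alone.

Measured so far in a functional assay on NCI-H460 cells (Homo sapiens) for cytotoxicity, read by sulforhodamine B assay, with a stated time of 48 h, tested at 1 uM; on this read-out lower numbers stand for a stronger effect and higher numbers for a weaker effect at the one concentration tested:
- compound 1, `COc1cc(-c2cc(/C=C/C(=O)c3ccc(N)cc3)[nH]n2)cc(OC)c1OC`: 78%
- compound 2, `COc1ccc(C(=O)/C=C/c2cc(-c3cc(OC)c(OC)c(OC)c3)n[nH]2)cc1OC`: 70%

Compound 2 has the lowest of the two numbers, and its nearest neighbour is compound 1, whose value lies higher, but the step of a number 8 percentage points lower from compound 1 to compound 2 (within the scatter) is within the scatter, so the two numbers cannot be told apart.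

Compound 3, `COc1cc(C(=O)/C=C/c2cc(-c3cc(OC)c(OC)c(OC)c3)n[nH]2)cc(OC)c1OC`, is not yet measured. It differs from compound 2 by methoxy in place of hydrogen on an aromatic carbon. Among the compounds with values here, no measured step in this assay bears on this change: the only step available, from compound 1 to compound 2, concerns the exchange of 3,4-dimethoxyphenyl for 4-aminophenyl on the carbonyl carbon, and that step was itself within the scatter. Nothing in the series therefore points to a step beyond the scatter in this assay in either direction.

Compound 3 is estimated at 68%, with a range of 50% to 85%. The step this estimate means, a number 2 percentage points lower from compound 2 to compound 3 (within the scatter), is expected to stay within the scatter.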

Compound 3, a percentage reported as activity, at one concentration (the size of the read-out at that concentration, not a potency): 89%
Estimate against measurement, compound 3: 21 percentage points below; the whole stated range lies below it.
By their numbers in this assay, from the lowest: compounds 2 and 1 (each within the scatter of the next); then compound 3.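

In this assay, methoxy in place of hydrogen on this aromatic carbon, ortho to a methoxy group and meta to a large group, gives a number 19 percentage points higher from compound 2 to compound 3 (beyond the scatter), so the effect at the one concentration tested is weaker. Within the data shown here, this is the first step beyond the scatter and shows that this position on the carbonyl-bearing ring can change the read-out, which the exchange of 4-aminophenyl for 3,4-dimethoxyphenyl, a number 8 percentage points lower from compound 1 to compound 2 (within the scatter), did not reveal. Nothing available explains the step.

As far as these compounds go, whether the change depends on methoxy itself remains open, since hydroxy, fluorine or ethoxy at this carbon would be needed to test it. A single concentration also leaves open how the effects of compound 2 and compound 3 compare at other concentrations.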